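The compounds below may be only part of what the source reports. "The series", "measured", "known", "first", "only" and "open" are said of these compounds alone.

Measured so far:
Compound 1, `CC1(C)N=C(N)N=C(N)N1c1cccc(C(O)c2ccccc2)c1`: 4.17
Compound 2, `CCCCCCCCCCCCCCOc1cccc(N2C(N)=NC(N)=NC2(C)C)c1`: 6.49

In a functional assay on L5178Y cells (Mus musculus) (on this read-out lower numbers stand for lower potency and higher numbers for higher potency (the scale is a negative logarithm)), compound 1 gives 4.17, the lowest of the two numbers. Its nearest neighbour, compound 2, gives 6.49 in this assay, a value far above compound 1 and well beyond the scatter of repeated measurements.

The unmeasured compound 3, `CCCCOc1cccc(N2C(N)=NC(N)=NC2(C)C)c1`, differs from compound 1 in one place: butoxy in place of hydroxy(phenyl)methyl on an aromatic carbon. Within the data shown here, no step between two measured compounds matches this change, so the expectation leans on what compound 1 and compound 2 show: compound 2, which carries a longer alkoxy chain on its aromatic ring, stands far higher than compound 1. Compound 3, with its shorter butoxy group, is expected to gain over compound 1, by a step of a number 1.13 log units higher from compound 1 to compound 3 (beyond the scatter), though not to reach compound 2. The estimate for compound 3 in this assay is 5.3, within 4.5 to 6.1.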

Compound 3, logarithm of the reciprocal of the active concentration, log(1/C): 5.95
Beside the measured number, compound 3's estimate is 0.65 log units below it; measured number inside the range.
By their numbers in this assay, from the lowest: compound 1; then compound 3; then compound 2.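

In this assay, placing butoxy instead of hydroxy(phenyl)methyl on this aromatic carbon, meta to a large group, gives a number 1.78 log units higher from compound 1 to compound 3 (beyond the scatter), so a short alkoxy chain without a ring is enough for a large rise. Taking decyl off the chain gives a number 0.54 log units lower from compound 2 to compound 3 (beyond the scatter), a modest step beside the first, so the much longer chain of compound 2 adds to what butoxy already reaches but is not needed for most of it. Nothing available gives a reason for either step.

The compounds shown leave open how the number moves with chain lengths between butoxy and the chain of compound 2, or with a shorter chain such as methoxy. They also leave open what a terminal amine or carboxylic acid on the butoxy chain would do.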